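Swapping the Nitrobenzyl Arm for a Chlorothienylmethyl Group

The compounds below may be only part of what the source reports. "The series", "measured", "known", "first", "only" and "open" are said of these compounds alone.

Measured compounds:
compound 1: `CCc1nc(N)nc(N)c1-c1ccc(NCc2ccc([N+](=O)[O-])cc2)cc1` gives 11 nM
compound 2: `Nc1nc(N)c(-c2ccc(NCc3ccc([N+](=O)[O-])cc3)cc2)c(COCc2ccccc2)n1` gives 0.2 nM

For the measured compounds named here, in an in vitro assay on CHOK cells for displacement of a labelled ligand from growth hormone secretagogue receptor type 1 (Homo sapiens) (on this read-out higher numbers stand for weaker inhibition and lower numbers for stronger inhibition), compound 2 stands lowest of the two numbers, with compound 1 as its only neighbour, separated by a 55-fold lower number from compound 1 to compound 2 (1.74 log units; beyond the scatter). Compound 3 `Nc1nc(N)c(-c2ccc(NCc3csc(Cl)c3)cc2)c(COCc2ccccc2)n1` differs from compound 2 in that (5-chlorothiophen-3-yl in place of 4-nitrophenyl on a saturated chain carbon bound to a nitrogen on an aromatic ring). Going by the values given here, the single measured step concerns the benzyloxy group, not this position, so no measured step bears on the change, and the direction is open. Compound 3 is therefore expected to give a number close to compound 2, with a modest shift to a higher number, a 5.0-fold higher number from compound 2 to compound 3 (0.70 log units; beyond the scatter). Compound 3 is estimated at 1 nM, ranging from 0.2 nM to 5 nM.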

Compound 3, half-maximal inhibitory concentration: 6.3 nM
Compound 3: middle estimate off by 6.3-fold (0.80 log units), on the low side; the whole stated range lies below it.
By their numbers in this assay, from the lowest: compound 2; then compounds 3 and 1 (each within the scatter of the next).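

In this assay, this position proves sensitive to the aryl group it carries: 5-chlorothiophen-3-yl in place of 4-nitrophenyl, on a saturated chain carbon bound to a nitrogen on an aromatic ring, gives a 32-fold higher number from compound 2 to compound 3 (1.50 log units; beyond the scatter). For the compounds shown here, the earlier step concerned only the benzyloxy group, so this is the first measured change at this arm, and compound 3 still reads 6.3 nM. Nothing measured here explains the step.

The ring, the chlorine and the nitro group all change together, leaving open which of them carries the step. Going by these compounds, how a 4-chlorophenyl group would read at this place also remains open.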